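This account rests on a few compounds, and the source may have more. Where it says the series, first, only, none or still open, it means among the compounds named here.

Compound 1 `O=C1[C@@H]2C(c3ccccc3)OC3(C(=O)c4ccccc4C3=O)[C@@H]2C(=O)N1c1ccc(Cl)c(Cl)c1` gives > 100000 nM in an assay on isolated protein for inhibition of phenylalanine--tRNA ligase, mitochondrial (Homo sapiens) (on this read-out lower numbers stand for stronger inhibition and higher numbers for weaker inhibition), which is a limit of the assay and not a number.
Compound 2 `Cc1ccc(N2C(=O)[C@H]3C(c4ccccc4)OC4(C(=O)c5ccccc5C4=O)[C@H]3C2=O)cc1Cl` gives > 100000 nM in this assay, again a limit of the assay.
Compound 3 `Cc1ccc(N2C(=O)[C@@H]3C(c4ccccc4)OC4(C(=O)c5ccccc5C4=O)[C@@H]3C2=O)cc1Cl` gives > 100000 nM in this assay, also a limit of the assay.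

Compound 2 therefore stands nowhere on a scale: its value is a limit, and so are the two other values shown, as the limit of > 100000 nM in this assay, at which 3 of the 3 values shown sit, records. The account follows the step from compound 2 to compound 4 `O=C1[C@H]2C(c3ccccc3)OC3(C(=O)c4ccccc4C3=O)[C@H]2C(=O)N1c1ccc(Cl)c(Cl)c1`, in which the change is chloro in place of methyl on an aromatic carbon.

Going by the values given here, two measured steps touch this change. Among the compounds with values here, the first is a step that the two limits leave unreadable from compound 1 to compound 3, the same exchange of methyl and chloro read in the other direction on the core drawn with the other configuration. The second is a step that the two limits leave unreadable from compound 2 to compound 3, a change of drawn configuration only, noted in the fact that one of compounds 2 and 3 is drawn with a defined configuration and the other without, at the place where they differ. Neither step has a readable size because the limit of > 100000 nM in this assay, at which 3 of the 3 values shown sit, leaves both ends without a number, so no direction and no size can be taken from them.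

On that basis compound 4 is expected to remain at the limit, with an estimate of 150000 nM in a range of 50000 nM to 1000000 nM. The expected step that the limit leaves unreadable from compound 2 to compound 4 is thus one that the limits will most likely leave unreadable.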

Compound 4, half-maximal inhibitory concentration: > 100000 nM
Compound 4 was reported as a limit; the forecaster's own chance of this, stated with the estimate: 85%; the middle value is on the limit's open side.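

Compound 4 is reported as a limit of the assay, as are compound 1 and compound 2, so neither chloro in place of methyl from compound 2 nor the change of drawn configuration from compound 1 gives a readable step. In this assay the compounds shown leave open whether any change on the shared core would give a number and not a limit.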